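From 3-methoxyphenyl to thiophen-2-yl on the carbonyl carbon

This account rests on a few compounds, and the source may have more. Where it says the series, first, only, none or still open, it means among the compounds named here.

Measured compounds:
- compound 1 `C=C(Br)C(=O)Nc1ccc(/C=C/C(=O)c2ccc(Cl)c(Cl)c2)cc1`: 1800 nM
- compound 2 `C=C(Br)C(=O)Nc1ccc(/C=C/C(=O)c2ccc(I)cc2)cc1`: 2800 nM
- compound 3 `C=C(Br)C(=O)Nc1ccc(/C=C/C(=O)c2cccc(OC)c2)cc1`: 850 nM

In a functional assay on MOLT-4 cells (Homo sapiens) for antiproliferative activity, with a stated time of 48 h (on this read-out higher numbers stand for weaker inhibition and lower numbers for stronger inhibition), compound 3 stands lowest of the three, at 850 nM on these numbers. Compound 4 `C=C(Br)C(=O)Nc1ccc(/C=C/C(=O)c2cccs2)cc1` differs from it by thiophen-2-yl in place of 3-methoxyphenyl on a carbonyl carbon, with thiophen-2-yl in place of 3-methoxyphenyl on a carbonyl carbon. The same place varies among the measured compounds, giving a 2.1-fold lower number from compound 1 to compound 3 (0.33 log units; beyond the scatter) and a 3.3-fold lower number from compound 2 to compound 3 (0.52 log units; beyond the scatter), while a 1.6-fold higher number from compound 1 to compound 2 (0.19 log units; within the scatter) is the smallest of these steps. None of them carries a five-membered ring, so they guide only the size of the step. Compound 3 already holds the low end at 850 nM in this set. The expected step in this assay is therefore a modest one upward, a 1.5-fold higher number from compound 3 to compound 4 (0.18 log units; within the scatter) by this estimate, possibly still within the scatter. For compound 4 the estimate is 1300 nM, with an expected range from 500 nM to 3500 nM on this read-out.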

Compound 4, half-maximal inhibitory concentration: 550 nM
Beside the measured number, compound 4's estimate is 2.4-fold (0.37 log units) above it, and the stated range covers the measured number.
By their numbers in this assay, from the lowest: compounds 4 and 3 (each within the scatter of the next); then compounds 1 and 2 (each within the scatter of the next).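

In this assay the carbonyl carbon carries a five-membered aromatic ring as well as a six-membered one: with a 1.5-fold lower number from compound 3 to compound 4 (0.19 log units; within the scatter) thiophen-2-yl and 3-methoxyphenyl cannot be told apart. Thiophen-2-yl also stands clear of the halogen-bearing rings, with a 5.1-fold lower number from compound 2 to compound 4 (0.71 log units; beyond the scatter) against 4-iodophenyl and a 3.3-fold lower number from compound 1 to compound 4 (0.51 log units; beyond the scatter) against 3,4-dichlorophenyl. Nothing given here accounts for these steps. On these data alone, whether furan-2-yl or pyridin-3-yl would sit with thiophen-2-yl at this place stays open. So does whether a thiophen-3-yl ring would give the same number.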